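A few compounds are considered here, and "the series" means these few. Any claim that something is new, unique, unknown or untested is made for them only; others in the source may bear on it.

Compound 1 `O=C(Sc1cccnc1C(=O)O)c1ccccc1Cl`: 75.8 h
Compound 2 `O=C(Sc1cccnc1C(=O)O)c1ccc(Cl)cc1`: 26.6 h
Compound 3 `O=C(Sc1cccnc1C(=O)O)c1cccc(C(F)(F)F)c1`: 10 h

These three numbers come from a physicochemical assay for pharmacokinetics, at pH 8; on this read-out higher numbers stand for a longer-lived compound and lower numbers for a shorter-lived compound. Compound 2, at 26.6 h, stands second highest of the three. Compound 3 lies below it and compound 1 above it, both gaps beyond the scatter.

Compound 4 `O=C(Sc1cccnc1C(=O)O)c1ccc([N+](=O)[O-])cc1` has not yet been measured. It differs from compound 2 by one change, nitro in place of chloro on an aromatic carbon, para to a large group.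

Going by the values given here, no measured pair differs in one place only, so no step speaks directly to this change. Among the compounds with values here, the only guide is loose. Compound 3, which carries trifluoromethyl, gives 10 h, a lower number than compound 2. On that single comparison, a downward step beyond the scatter is expected in this assay, though with wide uncertainty. The estimated change is a 4.4-fold lower number from compound 2 to compound 4 (0.65 log units; beyond the scatter). The estimate for compound 4 is 6 h, with an expected range from 2.5 h to 14 h.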

Compound 4, half-life: 4.7 h
Compound 4: the middle estimate sits 1.3-fold (0.11 log units) above what was measured, and the stated range covers the measured number.
By their numbers in this assay, from the lowest: compound 4; then compound 3; then compound 2; then compound 1.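

Going by these compounds alone, the step of a 5.7-fold lower number from compound 2 to compound 4 (0.75 log units; beyond the scatter) in this assay is the first comparison here between compounds that differ in one place, with nitro in place of chloro on an aromatic carbon, para to a large group. Within the data shown here, it shows that the half-life of this series responds to the group held at this position, which the earlier compounds, differing in more than one place, could not show on their own. Nothing measured here accounts for the size of this step.

A single step cannot show how other groups at this position would compare, such as an amine, a methoxy group or a nitrile. It also leaves open whether nitro would give a step of similar size at the other ring positions occupied by chloro in compound 1 or by trifluoromethyl in compound 3.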